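Compound 2 to compound 4: 4-fluorophenyl for pyridin-3-yl

This account rests on a few compounds, and the source may have more. Where it says the series, first, only, none or still open, it means among the compounds named here.

Compound 1 (`COc1cc2c(cc1OC)CN(c1ccc(C=O)cc1)CC2`) stands at 12.6% in an ADME assay on microsomes from liver (Mus musculus) for metabolic stability, read by LC-MS, with a stated time of 10 min, tested at 500 uM (a lower number here means that less of the compound is left, a higher number that more of the compound is left), and compound 2 (`COc1cc2c(cc1OC)CN(c1cccnc1)CC2`) at 9.5% in the same measurement, so these two lie within the scatter of each other at the low end of the three numbers. Compound 3 (`COc1cc2c(cc1OC)CN(c1cc(C(F)(F)F)cc(C(F)(F)F)c1)CC2`) reaches 83.1% in this assay and lies beyond the scatter from compound 2.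

The next step leads to compound 4 (`COc1cc2c(cc1OC)CN(c1ccc(F)cc1)CC2`), with 4-fluorophenyl in place of pyridin-3-yl on an amine nitrogen in a ring. Going by the values given here, no measured pair differs in one place only, so the size of this step rests on three values alone. Among the compounds with values here, compound 3 at 83.1% is the only measured compound with fluorine on its aryl group, which points upward, yet its trifluoromethyl groups are a far larger change than 4-fluorophenyl.

A moderate rise in this assay is expected, estimated as a number 15.5 percentage points higher from compound 2 to compound 4 (beyond the scatter) and so probably beyond the scatter but well short of the top value. For compound 4 the estimate is 25% in this assay with an expected range from 10% to 50% as the likely span.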

Compound 4, percent of the compound remaining: 2.5%
Estimate against measurement, compound 4: 22.5 percentage points above, and the stated range ends above it.
By their numbers in this assay, from the lowest: compounds 4, 2 and 1 (each within the scatter of the next, the first and the last beyond it); then compound 3.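

In this assay, 4-fluorophenyl in place of pyridin-3-yl on an amine nitrogen in a ring reads as a number 7 percentage points lower from compound 2 to compound 4 (within the scatter) and so does not separate the two compounds at this position. Fluoro in place of formyl on an aromatic carbon reads as a number 10.1 percentage points lower from compound 1 to compound 4 (beyond the scatter) and is the first one-place step in the series to leave the scatter, though only by a modest amount. Nothing at hand gives a reason for either step.

Going by these compounds alone, no one-place step yet connects compound 3 at 83.1% to the other compounds, so what sets it apart stays open. A plain phenyl or a phenyl with a single trifluoromethyl group on the shared core would allow a one-place reading against compound 4 and compound 3.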